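A few compounds are considered here, and "the series" means these few. Any claim that something is new, unique, unknown or untested is made for them only; others in the source may bear on it.

Measured in a functional assay on MCF7 cells (Homo sapiens) for cytotoxicity, read by sulforhodamine B assay, with a stated time of 48 h; a higher number here means a weaker inhibitor, a lower number a stronger inhibitor:
- compound 1 `CCc1ccccc1NS(=O)(=O)c1cccc(NC(=O)NCCCCl)c1`: 43000 nM
- compound 2 `CCCc1ccccc1NS(=O)(=O)c1cccc(NC(=O)NCCCCl)c1`: 18000 nM

Compound 2 holds the lower of the two numbers. Compound 3 `CCCc1ccccc1NS(=O)(=O)c1cccc(NC(=O)NCC)c1` differs from compound 2 by hydrogen in place of chloromethyl on a saturated chain carbon, two bonds along the chain from an amide-type nitrogen. The change is hydrogen in place of chloromethyl on a saturated chain carbon, two bonds along the chain from an amide-type nitrogen. Read one bond further out, 3-chloropropyl becomes ethyl. For the measured compounds named here, no measured step touches this place. Going by the values given here, the only measured step, a 2.4-fold lower number from compound 1 to compound 2 (0.38 log units; beyond the scatter), is modest and lies elsewhere on the molecule, so it offers only a rough guide to size. A move to a higher number is expected in this assay, with the step estimated as a 2.2-fold higher number from compound 2 to compound 3 (0.35 log units; beyond the scatter). For compound 3 the estimated value is 40000 nM, with an expected range of 15000 nM to 100000 nM.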

Compound 3, half-maximal inhibitory concentration: 40000 nM
Estimate against measurement, compound 3: no gap at the digits printed; the range from low to high includes it.
By their numbers in this assay, from the lowest: compound 2; then compounds 3 and 1 (each within the scatter of the next).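

In this assay, for the compounds shown here, 3-chloropropyl giving way to ethyl brings a 2.2-fold higher number from compound 2 to compound 3 (0.35 log units; beyond the scatter), the first reading at this place on the chain and a modest one. The change removes the chlorine and shortens the chain together, so the step belongs to the pair of changes and to neither alone. No supporting data bear on the origin of this step.

A plain propyl chain would separate chain length from the chlorine. Going by these compounds, whether a 3-fluoropropyl or 3-hydroxypropyl group tracks with 3-chloropropyl or with ethyl remains open.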